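A Methyl Step Carried onto a Second Core

The compounds below may be only part of what the source reports. "The series", "measured", "known", "first", "only" and "open" are said of these compounds alone.

Measured in a functional assay on MCF7 cells (Homo sapiens) for antiproliferative activity, read by MTT assay, with a stated time of 48 h; on this read-out lower numbers stand for stronger inhibition and higher numbers for weaker inhibition:
compound 1, `O=C(NS(=O)(=O)c1ccccc1)c1cncc(Br)c1`, 12900 nM
compound 2, `Cc1ccc(S(=O)(=O)NC(=O)c2cncc(Br)c2)cc1`, 9370 nM
compound 3, `O=C(NS(=O)(=O)c1ccccc1)c1cccnc1Cl`, 14000 nM

Compound 2 differs from compound 1 by methyl in place of hydrogen on an aromatic carbon. That change made a 1.4-fold lower number from compound 1 to compound 2 (0.14 log units; within the scatter). Compound 3 carries a different core; how its core differs from that of compound 1 is not broken down here. Compound 4, `Cc1ccc(C(=O)NS(=O)(=O)c2ccccc2)c(Cl)n1`, has not yet been measured. It differs from compound 3 by methyl in place of hydrogen on an aromatic carbon. The surroundings differ from the earlier case: here the methyl enters on a six-membered aromatic ring with one nitrogen, next to the ring nitrogen and meta to a chloro group, so this is the same kind of change, not the same change. Since the earlier methyl gave a 1.4-fold lower number from compound 1 to compound 2 (0.14 log units; within the scatter), a step of a 1.3-fold lower number from compound 3 to compound 4 (0.10 log units; within the scatter) is expected in this assay. Compound 4 is therefore estimated at 11000 nM, likely between 4500 nM and 28000 nM.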

Compound 4, half-maximal inhibitory concentration: 13400 nM
Compound 4: the middle estimate sits 1.2-fold (0.09 log units) below what was measured, within the range that was stated.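

In this assay, within the data shown here, the methyl gave a 1.0-fold lower number from compound 3 to compound 4 (0.02 log units; within the scatter) and so, on this second core as on the first, produced no step that stands clear of the scatter. The two steps do not differ: the same change on two cores in this assay, a 1.4-fold lower number (0.14 log units; within the scatter) from compound 1 to compound 2 and a 1.0-fold lower number (0.02 log units; within the scatter) from compound 3 to compound 4, 1.3-fold (0.12 log units) apart, within the scatter of two such steps. This shows that the change carried across these two cores without a readable difference, but since neither step is itself readable and the methyl enters a different place in each case, it shows no shared effect of methyl and no rule for other cores in this series.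

The compounds shown leave open whether a larger change at these places, such as an amine or a carboxylic acid in place of the hydrogen, would give a step beyond the scatter. They also leave open how the methyl would behave on any further core.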